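Extending a Side Chain: Expected Cytotoxicity of Compound 4

The compounds below may be only part of what the source reports. "The series", "measured", "known", "first", "only" and "open" are said of these compounds alone.

Of the compounds shown here, three have been measured in an ADME assay on cells (Homo sapiens) for cytotoxicity, read by polymerase chain reaction, with a stated time of 3 days; on this read-out higher numbers stand for lower toxicity in this test and lower numbers for higher toxicity in this test. Compound 1, `Cc1nc(NCc2ccccc2)nc(N[C@@H]2C[C@H](CO)[C@@H](O)[C@H]2O)c1-c1nc2cnccc2s1`, gives 25000 nM. Compound 2, `Cc1nc(N[C@H](C)c2ccccc2)nc(N[C@@H]2C[C@H](CO)[C@@H](O)[C@H]2O)c1-c1nc2cnccc2s1`, gives 25000 nM in this assay. The two differ by methyl in place of hydrogen on a saturated chain carbon bound to an aromatic carbon and a nitrogen on an aromatic ring, and that step made no change at the digits printed from compound 1 to compound 2 (within the scatter). Compound 3, `CCc1nccc2sc(-c3c(C)nc(N[C@H](C)c4ccc(OC(F)(F)F)cc4)nc3N[C@@H]3C[C@H](CO)[C@@H](O)[C@H]3O)nc12`, gives 7000 nM in this assay, the lowest of the three numbers; the difference between its core and the core of compound 1 is not broken down here.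

Compound 4, `CCCc1nccc2sc(-c3c(C)nc(N[C@H](C)c4ccc(OC(F)(F)F)cc4)nc3N[C@@H]3C[C@H](CO)[C@@H](O)[C@H]3O)nc12`, is not yet measured. It differs from compound 3 by methyl in place of hydrogen on a saturated chain carbon, two bonds along the chain from an aromatic carbon. This is the same kind of change as from compound 1 to compound 2, but the place differs: there the methyl entered on a saturated chain carbon bound to an aromatic carbon and a nitrogen on an aromatic ring, whereas here it enters on a saturated chain carbon two bonds along the chain from an aromatic carbon. Since the earlier step made no change at the digits printed from compound 1 to compound 2 (within the scatter), the step from compound 3 to compound 4 is expected to be no change at the digits printed from compound 3 to compound 4 (within the scatter). Compound 4 is therefore estimated at 7000 nM, between 3000 nM and 16000 nM, in this assay.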

Compound 4, half-maximal cytotoxic concentration: 13000 nM
Estimate against measurement, compound 4: 1.9-fold (0.27 log units) below, within the range that was stated.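

In this assay, the added methyl gave a 1.9-fold higher number from compound 3 to compound 4 (0.27 log units; within the scatter), so the propyl chain of compound 4 and the ethyl chain of compound 3 cannot be told apart in this test. Set beside the earlier case, the change looks much the same on both cores: the same change on two cores in this assay, no change at the digits printed (within the scatter) from compound 1 to compound 2 and a 1.9-fold higher number (0.27 log units; within the scatter) from compound 3 to compound 4, 1.9-fold (0.27 log units) apart, within the scatter of two such steps. This shows only that, in these two pairs, methyl in place of hydrogen left the number within the usual scatter; the methyl enters at a different place in each pair, so it does not show that the change would be as quiet at any other place or on any other core in the series.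

The compounds shown leave open what a butyl chain, or a chain ending in an amine or a carboxylic acid, would give in place of the propyl chain of compound 4. They also leave open whether the same pairs would stay this close in any test other than this assay.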